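This account rests on a few compounds, and the source may have more. Where it says the series, first, only, none or still open, it means among the compounds named here.

Measured compounds: compound 1 `Cc1nn(C)c2nc(NNC(=O)Nc3cc(Cl)nc(Cl)c3)cc(-c3ccc(Cl)s3)c12` with 29400 nM; compound 2 `CCCc1cc(NNC(=O)Nc2cc(Cl)nc(Cl)c2)nc2c1cnn2C` with 38700 nM; compound 3 `Cc1nn(C)c2nc(NNC(=O)Nc3cc(Cl)nc(Cl)c3)cc(C3CC3)c12` with 80800 nM.

In a functional assay on SW620/5-FU cells (Homo sapiens) for cytotoxicity, read by MTT assay, with a stated time of 48 h, in the presence of a further agent that is not named here (a higher number here means that more compound is needed for the effect, a lower number that less compound is needed), compound 2 stands second highest of the three numbers. Its nearest neighbour is compound 1, within the scatter, and its furthest is compound 3, beyond the scatter.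

Compound 4 `COc1ccc(-c2cc(NNC(=O)Nc3cc(Cl)nc(Cl)c3)nc3c2cnn3C)cc1` differs from compound 2 by 4-methoxyphenyl in place of propyl on an aromatic carbon. For the measured compounds named here, one measured step bears on this place: a 2.7-fold higher number from compound 1 to compound 3 (0.44 log units; beyond the scatter), where an aromatic group gave way to cyclopropyl. Read the other way, replacing a small non-aromatic group by an aromatic one lowered the number modestly. A similar modest fall is therefore expected here, as the step of a 1.9-fold lower number from compound 2 to compound 4 (0.29 log units; within the scatter). Compound 4 is thus estimated at 20000 nM, with a range from 9000 nM to 45000 nM.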

Compound 4, half-maximal effective concentration: 18500 nM
For compound 4 the middle estimate is 1.1-fold (0.03 log units) above the measured one, within the range that was stated.
By their numbers in this assay, from the lowest: compounds 4, 1 and 2 (each within the scatter of the next, the first and the last beyond it); then compound 3.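

In this assay, 4-methoxyphenyl in place of propyl gives a 2.1-fold lower number from compound 2 to compound 4 (0.32 log units; beyond the scatter), a modest step beyond the scatter. For the compounds shown here, the only earlier step at this place took an aromatic group away on the core of compound 1, whereas this one brings an aromatic ring in on the core of compound 2, and the number falls. No evidence available here accounts for this fall. From the compounds shown here alone, whether the methoxy group contributes beyond the phenyl ring itself remains open. So does how a morpholine or carboxylic acid on that ring, or a hexyl chain in place of propyl, would stand.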